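The source may report more compounds than this note shows. Statements on the series, on what has been measured and on what is new or still open speak of the compounds shown alone.

In a functional assay on SK-BR-3 cells (Homo sapiens) for antiproliferative activity (a lower number here means a stronger inhibitor, a higher number a weaker inhibitor), compound 1 `CC(C)=CCc1cc(C(=O)Nc2cc3ccc(OCC4CCCN(C)C4)c(C)c3oc2=O)ccc1O` gives 1300 nM, compound 2 `CCNCCCOc1ccc2cc(NC(=O)c3ccc(O)c(CC=C(C)C)c3)c(=O)oc2c1C` gives 720 nM and compound 3 `CC(C)=CCc1cc(C(=O)Nc2cc3ccc(OCCCNCC(N)=O)c(C)c3oc2=O)ccc1O` gives 2290 nM. Two steps place compound 3 among these: a 1.8-fold higher number from compound 1 to compound 3 (0.25 log units; within the scatter), and a 3.2-fold higher number from compound 2 to compound 3 (0.50 log units; beyond the scatter).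

Compound 4 `CC(C)=CCc1cc(C(=O)Nc2cc3ccc(OCCCN[C@H](C)c4ccccc4)c(C)c3oc2=O)ccc1O` changes only the group on the amine nitrogen of compound 3, with 1-phenylethyl in place of carbamoylmethyl on an amine nitrogen. Within the data shown here, no measured compound carries an aromatic ring on that nitrogen, so the evidence is indirect. The closest guide is the earlier change at the same nitrogen, carbamoyl in place of methyl, a 3.2-fold higher number from compound 2 to compound 3 (0.50 log units; beyond the scatter). Read backwards, it shows that the compound without the carbamoyl has the lower number. The remaining comparison, a 1.8-fold lower number from compound 1 to compound 2 (0.26 log units; within the scatter), shows that a different amine side chain need not move the number much.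

A modest step towards a lower number in this assay is therefore expected, though the new ring makes its size uncertain. The expected change is a 2.5-fold lower number from compound 3 to compound 4 (0.41 log units; beyond the scatter). For compound 4 the estimated value is 900 nM, with an expected range from 300 nM to 2500 nM.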

Compound 4, half-maximal inhibitory concentration: 1000 nM
Estimate against measurement, compound 4: 1.1-fold (0.05 log units) below; the measured number falls inside the stated range.
By their numbers in this assay, from the lowest: compounds 2, 4, 1 and 3 (each within the scatter of the next, the first and the last beyond it).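

In this assay, the amine nitrogen accepts a group carrying an aromatic ring: 1-phenylethyl in place of carbamoylmethyl gives a modest step (a 2.3-fold lower number from compound 3 to compound 4 (0.36 log units; beyond the scatter)). This entering group has no hydrogen-bond donors or acceptors, whereas carbamoylmethyl has both, so such groups on the leaving side are not needed to reach this level. Compound 4 also stays level with the two other amine side chains, with phenyl in place of hydrogen on the chain (a 1.4-fold higher number from compound 2 to compound 4 (0.14 log units; within the scatter)) and a change from the 1-methylpiperidin-3-yl group (a 1.3-fold lower number from compound 1 to compound 4 (0.11 log units; within the scatter)).

Still open, on these data alone, is whether the ring, the branching methyl or the loss of carbamoylmethyl drives the step from compound 3. A benzyl group, the opposite configuration of 1-phenylethyl or a carboxylic acid on the same chain would help to separate these. Nothing shown here explains the step.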